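Replacing chloro by a triazolyl sulfanyl group on the chloroacetamide

This account rests on a few compounds, and the source may have more. Where it says the series, first, only, none or still open, it means among the compounds named here.

Compound 1 `Cn1c(-c2ccc(NC(=O)CCl)cc2)nc(-c2ccccc2)c1-c1ccccc1` is the stronger of the two measured entries: in a functional assay on HT-29 cells (Homo sapiens) for cytotoxicity, read by MTT assay, with a stated time of 24 h, tested at 80 ug/mL (a higher number here means a stronger effect of the compound at the concentration tested, a lower number a weaker effect), compound 1 gives 76.1%, the higher of the two numbers. Compound 2 `Cc1ccc2oc(SCC(=O)Nc3ccc(-c4nc(-c5ccccc5)c(-c5ccccc5)n4C)cc3)nc2c1` sits nearest, and in this assay compound 2 gives 69.8%; the step of a number 6.3 percentage points lower from compound 1 to compound 2 (within the scatter) lies within the scatter.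

Compound 3 `Cn1cnnc1SCC(=O)Nc1ccc(-c2nc(-c3ccccc3)c(-c3ccccc3)n2C)cc1` is the unmeasured entry. Its difference from compound 1 is (4-methyl-4H-1,2,4-triazol-3-yl)sulfanyl in place of chloro on a saturated chain carbon bound to a carbonyl carbon. Going by the values given here, the only measured step that bears on this change is a number 6.3 percentage points lower from compound 1 to compound 2 (within the scatter), where a larger ring-bearing sulfanyl group entered at the same place without a shift beyond the scatter. A comparable outcome is expected here, so the step of a number 8.1 percentage points lower from compound 1 to compound 3 (within the scatter) is estimated to stay within the scatter, leaning slightly lower. Compound 3 is therefore expected to give 68%, with a likely range from 50% to 82%.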

Compound 3, a percentage reported as activity, at one concentration (the size of the read-out at that concentration, not a potency): 88%
Beside the measured number, compound 3's estimate is 20 percentage points below it, outside the stated range (above it).
By their numbers in this assay, from the lowest: compounds 2 and 1 (each within the scatter of the next); then compound 3.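

At the saturated chain carbon bound to a carbonyl carbon, a sulfanyl group can do more than match chloro: in this assay, (4-methyl-4H-1,2,4-triazol-3-yl)sulfanyl in place of chloro gives a number 11.9 percentage points higher from compound 1 to compound 3 (beyond the scatter) and thus a change beyond the scatter, which the earlier pair did not show. The ring on the sulfur also counts, as 4-methyl-4H-1,2,4-triazol-3-yl in place of 5-methyl-1,3-benzoxazol-2-yl gives a number 18.2 percentage points higher from compound 2 to compound 3 (beyond the scatter) with the rest of the structure unchanged. No measurement available here accounts for either rise.

It remains open whether the sulfur is needed at all, as the compounds shown include no amine, such as morpholine, on the same chain carbon. They also leave open how a longer chain between the sulfur and the carbonyl, or a triazole without its methyl group, would read.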